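Sulfonamide amine variation and oral clearance in mice

The source may hold more compounds than are shown below. What is called first, only, known or untested is meant among the compounds shown, and "the series" means these compounds.

The three measured compounds share a core and differ in the sulfonamide nitrogen substituents and in the ring that carries the sulfonyl group. Compound 1 `COCCNS(=O)(=O)c1ccc(C)c(C#Cc2cc(Cl)ccc2OCC(=O)O)c1` in an in vivo ADME assay on the whole organism (strain BALB/c) for pharmacokinetics, with Mus musculus as the target, read by LC-MS, at a dose of 5 mg/kg by the oral route (on this read-out lower numbers stand for slow clearance and higher numbers for fast clearance), gives 33.3 mL/min/kg. Compound 2 `CN(C)S(=O)(=O)c1ccc(F)c(C#Cc2cc(Cl)ccc2OCC(=O)O)c1` gives 10 mL/min/kg in this assay, and compound 3 `CN(C)S(=O)(=O)c1cncc(C#Cc2cc(Cl)ccc2OCC(=O)O)c1` gives 13.3 mL/min/kg in this assay. Compound 1 stands highest of the three numbers: the gap to compound 3, its nearest neighbour, is beyond the usual scatter, and the gap to compound 2 is wider still. Compounds 2 and 3 each differ from compound 1 in more than one place, so neither gap can be tied to a single change.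

Compound 4 `Cc1ccc(S(=O)(=O)N2CCOCC2)cc1C#Cc1cc(Cl)ccc1OCC(=O)O` has not yet been measured in this assay. Against compound 1 the change is morpholin-4-yl in place of (2-methoxyethyl)amino on a sulfonyl sulfur. Among the measured compounds shown here, no pair of measured compounds isolates this change, so the expectation rests on the trend that the open (2-methoxyethyl)amino compound sits highest. A downward step, of a size that may not clear the scatter, is expected: a 1.7-fold lower number from compound 1 to compound 4 (0.22 log units; within the scatter). Compound 4 is therefore estimated at 20 mL/min/kg, with a plausible range from 8 mL/min/kg to 45 mL/min/kg.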

Compound 4, clearance: 31.7 mL/min/kg
Beside the measured number, compound 4's estimate is 1.6-fold (0.20 log units) below it, within the range that was stated.
By their numbers in this assay, from the lowest: compounds 2 and 3 (each within the scatter of the next); then compounds 4 and 1 (each within the scatter of the next).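

Working notes on the sulfonyl position: in this assay, morpholin-4-yl in place of (2-methoxyethyl)amino on a sulfonyl sulfur gives a 1.1-fold lower number from compound 1 to compound 4 (0.02 log units; within the scatter), and this is the first step in the series that isolates one change. Closing the open chain into a six-membered ring, with the loss of the hydrogen-bond donor counted for this swap, therefore gives no readable difference in clearance on the core of compound 1, and the open (2-methoxyethyl)amino group is not singled out by this pair. Nothing at hand speaks to why this swap leaves the read-out unresolved.

Still open, on these data alone, is whether a piperidin-1-yl group or a piperazin-1-yl group on the same sulfonyl sulfur would also stay within the scatter of compound 1, which would test how far this position tolerates other ring amines. Also open is how the higher numbers of compound 1 and compound 4 relate to those of compound 2 and compound 3, since the compounds shown offer no single-change link between these two pairs.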